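Methyl in Place of Hydrogen: Expected Effect on Cytotoxicity

The source may hold more compounds than are shown below. What is called first, only, known or untested is meant among the compounds shown, and "the series" means these compounds.

Compound 1 `C(=N/Nc1nc(-c2ccccc2)cs1)\c1ccc(-n2ccnc2)cc1`: 21.8%
Compound 2 `Clc1ccc(-c2csc(N/N=C/c3ccc(-n4ccnc4)cc3)n2)cc1`: 32.1%
Compound 3 `C(=N/Nc1nc(-c2ccccc2)cs1)\c1ccc(-n2cncn2)cc1`: 28.4%

These three compounds were tested in an ADME assay on THP-1 cells (Homo sapiens) for cytotoxicity, read by MTT assay, tested at 50 ug/mL; on this read-out lower numbers stand for less inhibition and higher numbers for more inhibition at the one concentration tested (going by the name of the read-out). Compound 3 stands second highest of the three numbers, with compound 2 close by and compound 1 somewhat lower, though both of these gaps lie within the scatter. Compound 4 `Cc1ccc(-c2csc(N/N=C/c3ccc(-n4cncn4)cc3)n2)cc1` has not yet been measured. It differs from compound 3 in one place: methyl in place of hydrogen on an aromatic carbon. Read one bond further out, this is phenyl to 4-methylphenyl.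

For the measured compounds named here, one measured step bears on it. Chloro in place of hydrogen on an aromatic carbon, from compound 1 to compound 2, gave a number 10.3 percentage points higher from compound 1 to compound 2 (beyond the scatter), a modest rise beyond the scatter. Methyl entering at the same place is a different group, so the step is expected to be smaller: at most a modest rise, or none beyond the scatter.

Compound 4 is therefore expected to give 33% in this assay, with a range from 21% to 46%, meaning an expected step of a number 4.6 percentage points higher from compound 3 to compound 4 (within the scatter).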

Compound 4, a percentage reported as inhibition, at one concentration (the size of the read-out at that concentration, not a potency): 13.6%
The estimate for compound 4 lay 19.4 percentage points above the measured number; measured number outside the range, below it.
By their numbers in this assay, from the lowest: compounds 4, 1, 3 and 2 (each within the scatter of the next, the first and the last beyond it).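

In this assay, going from phenyl to 4-methylphenyl gave a number 14.8 percentage points lower from compound 3 to compound 4 (beyond the scatter), so a group added at this place on the ring can lower the number as well as raise it. The earlier rise, a number 10.3 percentage points higher from compound 1 to compound 2 (beyond the scatter), came with chloro on a compound carrying 1H-imidazol-1-yl, while this fall came with methyl on one carrying 1H-1,2,4-triazol-1-yl, so the two steps differ in both the entering group and the rest of the molecule. Nothing available explains the fall.

The compounds shown leave open whether methyl would lower the number on compound 1 and whether chloro would raise it on compound 3. They also leave open how a methoxy group or an amine at this place would read.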